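Aryl substituent change on a thromboxane receptor antagonist scaffold

This account rests on a few compounds, and the source may have more. Where it says the series, first, only, none or still open, it means among the compounds named here.

Compound 1 `CS(=O)(=O)Nc1ccccc1-c1ccc(COC2CC[C@H](N3CCCCCC3)[C@H]2OC/C=C\CCC(=O)O)cc1` and compound 2 `O=C(O)CC/C=C\CO[C@H]1C(OCc2ccc(-c3ccccc3CO)cc2)CC[C@@H]1N1CCCCCC1` share one core and differ in a single group. In a functional assay for antagonist activity at thromboxane A2 receptor (Rattus norvegicus) (on this read-out higher numbers stand for weaker binding and lower numbers for tighter binding), compound 1 gives 3.98 nM, and compound 2 gives 6.31 nM. Compound 2 thus carries the higher of the two numbers, but the step of a 1.6-fold higher number from compound 1 to compound 2 (0.20 log units; within the scatter) lies within the scatter. Compound 3 `O=C(O)CC/C=C\CO[C@H]1C(OCc2ccc(-c3ccccc3O)cc2)CC[C@@H]1N1CCCCCC1` introduces the change (hydroxy in place of hydroxymethyl on an aromatic carbon). Within the data shown here, the only measured step bearing on this site stayed within the scatter, so a step of a 1.0-fold lower number from compound 2 to compound 3 (0.00 log units; within the scatter) is expected, none beyond the scatter. Compound 3 is therefore estimated to give 6.3 nM in this assay, with a range from 2.5 nM to 16 nM.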

Compound 3, dissociation constant: 20 nM
Compound 3: middle estimate off by 3.2-fold (0.50 log units), on the low side, outside the stated range (above it).
By their numbers in this assay, from the lowest: compounds 1 and 2 (each within the scatter of the next); then compound 3.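

On the aromatic carbon ortho to a large group, the site is not indifferent to its substituent, as the earlier pair suggested: the change gives a 3.2-fold higher number from compound 2 to compound 3 (0.50 log units; beyond the scatter), and the wider comparison gives a 5.0-fold higher number from compound 1 to compound 3 (0.70 log units; beyond the scatter). Hydrogen-bond donor and acceptor counts are the same for hydroxymethyl and hydroxy, so those counts do not separate compound 2 from compound 3 in this assay. No data at hand explain the shift. Still open, from the compounds shown here alone, is how an amine, a carboxylic acid or a longer chain such as hydroxyethyl would read at this carbon.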